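Swapping fluoro for methyl in compound 3

The source may hold more compounds than are shown below. What is called first, only, known or untested is meant among the compounds shown, and "the series" means these compounds.

Compound 1 `O=C(NS(=O)(=O)c1ccccc1)c1cccnc1`: 9500 nM
Compound 2 `O=C(NS(=O)(=O)c1ccc(Cl)cc1)c1cncc(C(=O)NS(=O)(=O)c2ccc(Cl)cc2)c1`: 1700 nM
Compound 3 `O=C(NS(=O)(=O)c1ccc(F)cc1)c1ccncc1`: 9200 nM

In a functional assay on RAW264.7 cells (Mus musculus) for inhibition (on this read-out higher numbers stand for weaker inhibition and lower numbers for stronger inhibition), compound 3 and compound 1 lie within the usual scatter of each other. Compound 2, at 1700 nM, has a lower number than compound 3, which means stronger inhibition, and that gap lies beyond the scatter.

Compound 4 `Cc1ccc(S(=O)(=O)NC(=O)c2ccncc2)cc1` has not been measured yet. Its difference from compound 3 is methyl in place of fluoro on an aromatic carbon, para to a large group. Among the measured compounds shown here, no measured pair tests this swap on its own, so any forecast is tentative. The nearest guide is that compound 1 at 9500 nM and compound 3 at 9200 nM differ in structure yet give matching values. The expected step of a 1.0-fold lower number from compound 3 to compound 4 (0.01 log units; within the scatter) is therefore none beyond the scatter. Compound 4 is expected at 9000 nM, with an estimated range of 4000 nM to 20000 nM.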

Compound 4, half-maximal inhibitory concentration: 9800 nM
Estimate against measurement, compound 4: 1.1-fold (0.04 log units) below, within the range that was stated.
By their numbers in this assay, from the lowest: compound 2; then compounds 3, 1 and 4 (each within the scatter of the next).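

In this assay, methyl in place of fluoro on an aromatic carbon, para to a large group, gives a 1.1-fold higher number from compound 3 to compound 4 (0.03 log units; within the scatter). Among the compounds shown here, this is the first pair here that differs in one place only, and it shows that at this position the assay does not separate these two groups, each of one heavy atom. Nothing measured here offers an explanation for this match.

The compounds shown leave open whether an amine, a carboxylic acid or a longer chain at this same position would move the number beyond the scatter. They also leave open whether methyl and fluoro would read alike on the core of compound 2.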